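A few compounds are considered here, and "the series" means these few. Any claim that something is new, unique, unknown or untested is made for them only; others in the source may bear on it.

Working notes on the series. Compound 1 `CCOC(=O)c1c(-c2cccc(OC)c2)[nH]c2cc(OC)ccc2c1=O` is the parent; compound 2 `CCOC(=O)c1c(-c2cccc(Oc3ccccc3)c2)[nH]c2cc(OC)ccc2c1=O` differs from it by phenyl in place of methyl on an oxygen on an aromatic ring. Compound 3 `CCOC(=O)c1c(-c2cccc(OC)c2)[nH]c2cc(Cl)c(OC)cc2c1=O` carries the same side ring as compound 1 on a different core; the difference between the two cores is not broken down here.

In an ADME assay on Raji cells (Homo sapiens) for cytotoxicity, read by luminescence, with a stated time of 72 h (on this read-out lower numbers stand for an effect already at smaller amounts and higher numbers for an effect only at larger amounts of compound), compound 1 gives > 21500 nM, which is a limit of the assay rather than a number. Compound 2 likewise gives only a limit, > 21500 nM. Compound 3 also returns only a limit, > 21500 nM. The step that the two limits leave unreadable from compound 1 to compound 2 therefore cannot be sized. For the measured compounds named here, every value so far sits at the limit of > 21500 nM in this assay, at which 3 of the 3 values shown sit.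

Compound 4 `CCOC(=O)c1c(-c2cccc(Oc3ccccc3)c2)[nH]c2cc(Cl)c(OC)cc2c1=O` has not yet been measured in this assay; it differs from compound 3 by phenyl in place of methyl on an oxygen on an aromatic ring, the same change that turns compound 1 into compound 2. Expected for compound 4 is a step that the limit leaves unreadable from compound 3 to compound 4 from compound 3, resting on compound 1 and compound 2 both sitting at the limit of > 21500 nM in this assay, at which 3 of the 3 values shown sit. The estimate for compound 4 in this assay is 30000 nM, with a range from 15000 nM to 80000 nM, and most probably again only a limit will be reported.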

Compound 4, half-maximal effective concentration: > 21500 nM
Compound 4: only a limit was reported; the forecaster's own chance of this, stated with the estimate: 85%; the middle value does not contradict the limit.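

In this assay compound 4 gives > 21500 nM, which is a limit and not a number, so the step from compound 3 to compound 4 cannot be read, and the series offers no new comparison: the limit of > 21500 nM in this assay, at which 4 of the 4 values shown sit. The compounds shown leave open how large any effect of phenyl in place of methyl is on either core.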